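The source may report more compounds than this note shows. Statements on the series, on what has been measured and on what is new or still open speak of the compounds shown alone.

Measured so far in an assay for binding affinity to dual specificity mitogen-activated protein kinase kinase 4 (Homo sapiens), read by KINOMEscan, tested at 100 nM; on this read-out higher numbers stand for a weaker effect at the one concentration tested and lower numbers for a stronger effect:
compound 1 `CCCS(=O)(=O)Nc1ccc(F)c(C(=O)c2n[nH]c3ncc(-c4ccc(O)cc4)cc23)c1F` gives 0.75%
compound 2 `CCCS(=O)(=O)Nc1ccc(F)c(C(=O)c2n[nH]c3ncc(-c4cc(Cl)cc(Cl)c4)cc23)c1F` gives 73%
compound 3 `CCCS(=O)(=O)Nc1ccc(F)c(C(=O)c2n[nH]c3ncc(-c4ccc(C(C)(C)C)cc4)cc23)c1F` gives 46%

Compound 3 stands second highest of the three numbers; compound 2 is nearest and compound 1 furthest, and both gaps lie beyond the scatter. The step of a number 45.3 percentage points higher from compound 1 to compound 3 (beyond the scatter) came with tert-butyl in place of hydroxy on an aromatic carbon, and the step of a number 27 percentage points lower from compound 2 to compound 3 (beyond the scatter) with 4-(tert-butyl)phenyl in place of 3,5-dichlorophenyl on an aromatic carbon. Compound 4 `CCCS(=O)(=O)Nc1ccc(F)c(C(=O)c2n[nH]c3ncc(-c4ccc(S(=O)(=O)NC)cc4)cc23)c1F` is not yet measured. It differs from compound 3 as follows: methylsulfamoyl in place of tert-butyl on an aromatic carbon. The step from compound 1 to compound 3 bears most directly on this change, since it was the departure from hydroxy that carried the large rise, and the entering methylsulfamoyl again brings 1 hydrogen-bond donor and 2 hydrogen-bond acceptors where tert-butyl has none. A large downward step is therefore expected, a number 31 percentage points lower from compound 3 to compound 4 (beyond the scatter), though compound 2, also without such a group, leaves open how far it reaches. The estimate for compound 4 is 15%, expected to fall between 1% and 50%.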

Compound 4, a percentage reported as activity, at one concentration (the size of the read-out at that concentration, not a potency): 1.2%
Compound 4: middle estimate off by 13.8 percentage points, on the high side; low and high end bracket the measured number.
By their numbers in this assay, from the lowest: compounds 1 and 4 (each within the scatter of the next); then compound 3; then compound 2.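

Methylsulfamoyl in place of hydroxy gives a number 0.5 percentage points higher from compound 1 to compound 4 (within the scatter), so in this assay the low read-out at this position, para to a large group, is no longer tied to hydroxy alone. Methylsulfamoyl also gives a number 44.8 percentage points lower from compound 3 to compound 4 (beyond the scatter) and, as 4-(methylsulfamoyl)phenyl, a number 71.8 percentage points lower from compound 2 to compound 4 (beyond the scatter), so across these four compounds the low numbers go with the two groups that carry a hydrogen-bond donor, and no compound here goes against that. No measurement shown gives a reason for this link.

On these data alone, whether the donor or the acceptors matter remains open, and dimethylsulfamoyl or methoxy at this position would separate the two. Also open, as far as these compounds go, is whether an amine or a carboxylic acid there would give an equally low number, and a single-concentration read-out this low cannot rank compound 1 and compound 4.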